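Isobutyl for isopropyl on the ring amine nitrogen

A few compounds are considered here, and "the series" means these few. Any claim that something is new, unique, unknown or untested is made for them only; others in the source may bear on it.

Measured so far in an ADME assay on a cell-free system (plasma, Mus musculus) for metabolic stability, read by LC-MS, tested at 2 uM; a higher number here means that the compound lasts longer, a lower number that the compound disappears faster:
- compound 1 `CC(C)N1CCC(c2ccc3c(c2)oc(=O)n3C(=O)NCCCCc2ccccc2)CC1` with a half-life of 0.667 h
- compound 2 `CN1CCC(c2ccc3c(c2)oc(=O)n3C(=O)NCCCCc2ccc(F)cc2)CC1` with a half-life of 0.333 h

Compound 1 stands within the scatter of compound 2, so these two numbers set no order. Compared with compound 1, compound 3 `CC(C)CN1CCC(c2ccc3c(c2)oc(=O)n3C(=O)NCCCCc2ccccc2)CC1` has isobutyl in place of isopropyl on an amine nitrogen in a ring. Going by the values given here, no measured pair shows this change, so no step beyond the scatter is expected in this assay. The expected 1.1-fold lower number from compound 1 to compound 3 (0.05 log units; within the scatter) stays within the scatter. Compound 3 is estimated at 0.6 h as its half-life, with an expected range from 0.27 h to 1.3 h for repeat measurements.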

Compound 3, half-life: 1 h
The estimate for compound 3 lay 1.7-fold (0.22 log units) below the measured number; the measured number falls inside the stated range.
By their numbers in this assay, from the lowest: compounds 2, 1 and 3 (each within the scatter of the next, the first and the last beyond it).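

In this assay, isobutyl in place of isopropyl on the ring amine nitrogen gives a 1.5-fold higher number from compound 1 to compound 3 (0.18 log units; within the scatter). Going by these compounds alone, this is the first pair that differs in one place, and it shows that this one-carbon change on the piperidine nitrogen sets no order between the two compounds. No available data bear on the reason for this result.

Still open, on these data alone, is whether a bulkier group on this nitrogen, such as benzyl or cyclohexyl, would also stay within the scatter. The same question holds for a free amine hydrogen there.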